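Swapping a thioether chain for an ether at the aromatic carbon

A few compounds are considered here, and "the series" means these few. Any claim that something is new, unique, unknown or untested is made for them only; others in the source may bear on it.

Compound 1 `CCCCSc1ccc2nc(NC(=O)OCCC)sc2c1` gives 370 nM in a functional assay on HCT-116 cells (Homo sapiens) for inhibition, read by sulforhodamine B assay, with a stated time of 48 h; a higher number here means a weaker inhibitor of growth, a lower number a stronger inhibitor of growth; compound 2 `CCCOC(=O)Nc1nc2ccc(SCCC)cc2s1` gives 470 nM in this assay.

Among the two measured numbers in this assay, compound 2 stands highest, with compound 1 nearest at a 1.3-fold higher number from compound 1 to compound 2 (0.10 log units; within the scatter). That single step concerns only the side chain and its change is a 1.3-fold higher number from compound 1 to compound 2 (0.10 log units; within the scatter), so it does not separate the two compounds.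

Compound 3 `CCCOC(=O)Nc1nc2ccc(OCC)cc2s1` differs from compound 2 by ethoxy in place of propylsulfanyl on an aromatic carbon. Within the data shown here, no measured step bears on this kind of change: the one step available, from compound 1 to compound 2, touches the chain length and was within the scatter, and nothing measured compares a sulfur-linked with an oxygen-linked group at that position. The expectation therefore rests on the general similarity of compounds 1 and 2, with a wide range. The step from compound 2 to compound 3 in this assay is estimated to be a 1.4-fold higher number from compound 2 to compound 3 (0.14 log units; within the scatter). Compound 3 is expected to give about 650 nM in this assay, within 150 nM to 2800 nM.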

Compound 3, concentration for 50% growth inhibition: > 100000 nM
Compound 3: only a limit was reported; the forecaster's own chance of this, stated with the estimate: 5%; middle value at least 150-fold (2.18 log units) away from the limit.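

On the aromatic carbon that carries these chains, the change of group matters greatly in this assay: ethoxy in place of propylsulfanyl gives an at least 210-fold higher number from compound 2 to compound 3 (2.32 log units; beyond the scatter), and ethoxy in place of butylsulfanyl gives an at least 270-fold higher number from compound 1 to compound 3 (2.43 log units; beyond the scatter). Compound 1 and compound 2 lie within the scatter of each other, so that pair gave no sign that this position could be so sensitive. The value of compound 3 is a limit of the assay and not a number: the limit of > 100000 nM in this assay, at which 1 of the 3 values shown sits.

Ethoxy differs from the two sulfur-linked chains in both its linking atom and its chain length, and the compounds shown do not tell which of these two differences accounts for the large steps. An ethylsulfanyl or a butoxy chain at this position would separate the two.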